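From Two Assay Limits to an Estimate

The source may report more compounds than this note shows. Statements on the series, on what has been measured and on what is new or still open speak of the compounds shown alone.

Two related compounds have been tested so far for their effect on the growth of breast cancer cells. In a functional assay on MCF7 cells (Homo sapiens) for antiproliferative activity, read by MTT assay, with a stated time of 72 h (on this read-out higher numbers stand for weaker inhibition and lower numbers for stronger inhibition), compound 1 (`C/C(=N\NC(=O)c1cccc(S(=O)(=O)N2CCOCC2)c1)c1ccc(O)cc1`) gives > 100000 nM, which is a limit of the assay and not a number. Compound 2 (`O=C(N/N=C/c1ccccn1)c1cccc(S(=O)(=O)N2CCOCC2)c1`) gives > 100000 nM, which is also a limit. Compound 2 therefore has no exact value, and the two results offer no measured difference to learn from.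

The next compound, compound 3 (`O=C(N/N=C/c1cc(Br)ccc1O)c1cccc(S(=O)(=O)N2CCOCC2)c1`), changes one group of compound 2. It carries 5-bromo-2-hydroxyphenyl in place of pyridin-2-yl on a carbon with a double bond to nitrogen. For the measured compounds named here, no measured pair yet shows what a change at this place does, so any forecast is loose.

The limit of compound 2 at > 100000 nM leaves a readable change in only one direction, toward stronger inhibition. The expected move in this assay is a moderate one, estimated as an at least 4.0-fold lower number from compound 2 to compound 3 (0.60 log units; beyond the scatter). Compound 3 is expected at about 25000 nM, with an estimated range from 4000 nM to 100000 nM.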

Compound 3, half-maximal inhibitory concentration: 26600 nM
Estimate against measurement, compound 3: 1.1-fold (0.03 log units) below, within the range that was stated.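

For the compounds shown here, compound 3 is the first compound here to give an exact number in this assay, which shows that the group on a carbon with a double bond to nitrogen can affect this result. Putting 5-bromo-2-hydroxyphenyl in place of pyridin-2-yl at this place gives an at least 3.7-fold lower number from compound 2 to compound 3 (0.57 log units; beyond the scatter), a step beyond the usual scatter of repeated measurements. The true step may be larger, because it starts from an assay limit and not from an exact number: the limit of > 100000 nM in this assay, at which 2 of the 3 values shown sit.

This single change removes the ring nitrogen of pyridin-2-yl and brings in a ring of carbon only, a hydroxyl group and a bromine atom all at once, and the compounds shown do not separate the share of each in the step. On these data alone, it remains open whether an unsubstituted phenyl ring, a phenyl ring carrying only the hydroxyl group or only the bromine atom, or a ring with chlorine in place of bromine would give a similar number.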